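Working notes: aryl to tert-butyl exchange at a ring carbon

A few compounds are considered here, and "the series" means these few. Any claim that something is new, unique, unknown or untested is made for them only; others in the source may bear on it.

Measured so far in a functional assay on NPC-TW01 cells (Homo sapiens) for inhibition, read by MTT assay, with a stated time of 72 h; a higher number here means a weaker inhibitor of growth, a lower number a stronger inhibitor of growth:
compound 1 `CN(C)/C=N/c1c(C=O)c(-c2ccccc2)nn1-c1cccc([N+](=O)[O-])c1`: 36700 nM
compound 2 `COc1ccc(-n2nc(-c3ccccc3)c(C=O)c2/N=C/N(C)C)cc1`: 20200 nM
compound 3 `Cc1ccc(-c2nn(-c3ccccc3)c(/N=C/N(C)C)c2C=O)cc1`: 9700 nM

Compound 3 gives the lowest number of the three; the numbers of compound 2 and compound 1 both stand higher, and each of those gaps goes beyond the usual scatter. Going by the values given here, the only single-point step among the measured compounds, a 1.8-fold lower number from compound 1 to compound 2 (0.26 log units; within the scatter), concerns the group on the aromatic nitrogen and stays within the scatter.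

Compound 4 `CN(C)/C=N/c1c(C=O)c(C(C)(C)C)nn1-c1ccccc1` has not been measured. It differs from compound 3 by tert-butyl in place of 4-methylphenyl on an aromatic carbon. Among the compounds with values here, no measured step touches this position or this kind of exchange: the one step compared so far swaps one aromatic group for another on a nitrogen, whereas here a six-membered aromatic ring on a carbon gives way to a group with no ring. The measured data therefore give no direct guide to the size or direction of the step in this assay, and the estimate rests on the general observation that the measured compounds all carry an aromatic group at this carbon.

The step from compound 3 to compound 4 is expected to be a 2.6-fold higher number from compound 3 to compound 4 (0.41 log units; beyond the scatter), toward a higher number, with wide uncertainty. Compound 4 is expected to give 25000 nM, within a range from 8000 nM to 80000 nM.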

Compound 4, concentration for 50% growth inhibition: > 50000 nM
Compound 4 ended at the assay's limit; the forecaster's own chance of this, stated with the estimate: 10%; at least 2.0-fold (0.30 log units) between middle value and limit.
By their numbers in this assay, from the lowest: compound 3; then compounds 2 and 1 (each within the scatter of the next). At a limit, above all of these: compound 4.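

In this assay, tert-butyl in place of 4-methylphenyl on an aromatic carbon gives an at least 5.1-fold higher number from compound 3 to compound 4 (0.71 log units; beyond the scatter). Going by these compounds alone, this is the first step that lies beyond the scatter, whereas the earlier exchange of one aromatic group for another on the ring nitrogen, a 1.8-fold lower number from compound 1 to compound 2 (0.26 log units; within the scatter), stays within it; the carbon next to the ring nitrogen is therefore a place where the series responds to a change of group, and in the direction of a weaker inhibitor of growth. Compound 4 stands at a limit of the assay and not at a number, so the step gives only a lower bound on the size of the change: the limit of > 50000 nM in this assay, at which 1 of the 4 values shown sits.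

This single pair replaces a six-membered aromatic ring with a group that has no ring and also changes the number of heavy atoms, so it cannot separate the loss of the ring from the change in size. Cyclohexyl, a pyridine ring, a longer chain such as n-butyl or a phenyl ring bearing an amine at this carbon would each test a different part of that question.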